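A few compounds are considered here, and "the series" means these few. Any claim that something is new, unique, unknown or untested is made for them only; others in the source may bear on it.

Three compounds sharing one core were tested in a functional assay on BGC-823 cells (Homo sapiens) for inhibition, read by MTT assay, with a stated time of 72 h; on this read-out lower numbers stand for stronger inhibition and higher numbers for weaker inhibition. Compound 1 `O=C(NCc1ccc(NC(=O)c2cccc(F)c2N2CCCC2)cc1)OCc1cccnc1` gives > 100000 nM, which is a limit of the assay and not a number. Compound 3 `O=C(NCc1ccc(NC(=O)c2cc(C(F)(F)F)ccc2N2CCCC2)cc1)OCc1cccnc1` gives > 100000 nM, which is also a limit. Among the compounds with values here, compound 2 `O=C(NCc1ccc(NC(=O)c2ccc(F)cc2N2CCCC2)cc1)OCc1cccnc1` gives 74500 nM, the only actual number among the three.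

Compound 4 `Cc1ccc(C(=O)Nc2ccc(CNC(=O)OCc3cccnc3)cc2)c(N2CCCC2)c1` has methyl in place of fluoro on an aromatic carbon of compound 2: methyl in place of fluoro on an aromatic carbon. Within the data shown here, no measured pair shows this change, so no step beyond the usual scatter is expected in this assay, in either direction. The estimated step of a 1.1-fold higher number from compound 2 to compound 4 (0.03 log units; within the scatter) reflects that expectation. For compound 4 the expected value is 80000 nM, with an estimated range of 35000 nM to 100000 nM.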

Compound 4, half-maximal inhibitory concentration: > 100000 nM
Compound 4 gave a limit, no number; the forecaster's own chance of this, stated with the estimate: 40%; middle value at least 1.2-fold (0.09 log units) from the limit.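

In this assay, within the data shown here, this is the first measured pair for methyl in place of fluoro on the aromatic carbon meta to a pyrrolidin-1-yl group, and it gives an at least 1.3-fold higher number from compound 2 to compound 4 (0.12 log units; that floor lies within the scatter). Methyl at this position therefore brings no stronger inhibition than fluoro. The step is only a floor, and its true size stays hidden, because compound 4 sits at a limit of the assay and not at a number: the limit of > 100000 nM in this assay, at which 3 of the 4 values shown sit.

Still open, from the compounds shown here alone, is whether an amine, a methoxy group or a carboxylic acid at this position would give a real number. Also open, going by these compounds, is whether any of them would inhibit more strongly than fluoro.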